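This account rests on a few compounds, and the source may have more. Where it says the series, first, only, none or still open, it means among the compounds named here.

Of the compounds shown here, two sharing one core have been measured in an assay on mitochondria from L6 cells (Rattus norvegicus) for activation, with a stated time of 90 min; a lower number here means that less compound is needed, a higher number that more compound is needed for the effect. Compound 1 `CCc1cccc(Nc2nc3nonc3nc2O)c1` gives 25200 nM in this assay. Compound 2 `Cc1ccc(C(F)(F)F)cc1Nc1nc2nonc2nc1O` gives 32800 nM in this assay, the higher of the two numbers, though its gap to compound 1 lies within the scatter of repeated measurements, so the two stand level. Compound 3 `Oc1nc2nonc2nc1Nc1cccc(C(F)(F)F)c1` has not yet been measured in this assay. It differs from compound 2 in one place: hydrogen in place of methyl on an aromatic carbon. Going by the values given here, no step between two measured compounds that changes only this place has been recorded, so the size of this step cannot be read off from the numbers at hand. Compound 1, at 25200 nM, and compound 2, at 32800 nM, differ in more than one place yet stand within the scatter of each other; on that footing small changes to this part of the molecule appear to matter little. For compound 3 the expectation is therefore a step of about a 1.1-fold lower number from compound 2 to compound 3 (0.04 log units; within the scatter), which is none beyond the scatter. The estimate for compound 3 in this assay is 30000 nM, with a range from 10000 nM to 90000 nM.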

Compound 3, half-maximal effective concentration: 13300 nM
The estimate for compound 3 lay 2.3-fold (0.35 log units) above the measured number, and the stated range covers the measured number.
By their numbers in this assay, from the lowest: compounds 3, 1 and 2 (each within the scatter of the next, the first and the last beyond it).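

In this assay the methyl on the aromatic carbon, ortho to a large group and para to a trifluoromethyl group, now has a step of its own: hydrogen in its place gives a 2.5-fold lower number from compound 2 to compound 3 (0.39 log units; beyond the scatter), a modest change but the first at this position to pass beyond the scatter, which the level standing of compound 1 and compound 2 had not suggested. This place therefore responds to a change of a single carbon, and here the compound without the methyl needs less compound for the effect. The exchange of ethyl for trifluoromethyl gives a 1.9-fold lower number from compound 1 to compound 3 (0.28 log units; within the scatter), which stays within the scatter, so compound 1 and compound 3 stand level and this pair shows no preference between those two groups. Nothing at hand bears on the reason for either step.

The compounds shown leave open how a chlorine atom, a methoxy group or an amine would behave on this aromatic carbon, and whether the step seen on losing the methyl would keep its size without the trifluoromethyl group.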